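Amino for nitro on a trimethoxyphenyl beta-lactam

This account rests on a few compounds, and the source may have more. Where it says the series, first, only, none or still open, it means among the compounds named here.

Measured compounds:
compound 1, `COc1cc(N2C(=O)[C@H](Oc3ccccc3)[C@H]2c2ccc(C#N)cc2)cc(OC)c1OC`, 168000 nM
compound 2, `COc1cc(N2C(=O)[C@@H](Oc3ccccc3)[C@H]2c2ccc([N+](=O)[O-])cc2)cc(OC)c1OC`, 63000 nM

In a functional assay on MCF7 cells (Homo sapiens) for antiproliferative activity, read by MTT assay, with stated times of 24 h and 72 h (on this read-out lower numbers stand for stronger inhibition and higher numbers for weaker inhibition), compound 2 stands at the lower of the two numbers. Going by the values given here, its nearest neighbour is compound 1, whose value lies beyond the scatter above it; the two structures differ in more than one place, so only their two values are compared here, and no single step is drawn between them. Compound 3, `COc1cc(N2C(=O)[C@@H](Oc3ccccc3)[C@H]2c2ccc(N)cc2)cc(OC)c1OC`, has not yet been measured in this assay. Its difference from compound 2 is amino in place of nitro on an aromatic carbon. Among the compounds with values here, two measured compounds give no basis for a pattern, and no step between measured compounds exists that would show what such a change does. On that footing a modest downward move is expected, not far beyond the scatter, with a real chance of none at all. The step that this estimate means is a 1.6-fold lower number from compound 2 to compound 3 (0.20 log units; within the scatter), stated as an expectation. Compound 3 is therefore estimated at 40000 nM in this assay, with a range from 10000 nM to 150000 nM.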

Compound 3, half-maximal inhibitory concentration: 160000 nM
Estimate against measurement, compound 3: 4.0-fold (0.60 log units) below; the whole stated range lies below it.
By their numbers in this assay, from the lowest: compound 2; then compounds 3 and 1 (each within the scatter of the next).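

In this assay, going by these compounds alone, the change from 4-nitrophenyl to 4-aminophenyl gives a 2.5-fold higher number from compound 2 to compound 3 (0.40 log units; beyond the scatter) and provides the first comparison that differs in only one place. It shows that the group on this aromatic carbon, para to a large group, matters in this assay: with the rest of the structure unchanged, nitro goes with stronger inhibition than amino, although the step is modest and both numbers remain high. No measurement shown bears on the cause of this step.

Compound 1 carries a nitrile at this place but differs from compound 2 in more than one place, so the effect of the nitrile cannot be read from its value alone. The compounds shown leave open how an acetamide, a carboxylic acid or a methoxy group at the same position would compare with nitro and amino, and whether the step from nitro to amino would keep its direction on a different arrangement of the shared core.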